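Ethyl in Place of Bromo: An Expected Gain

The compounds below may be only part of what the source reports. "The series", "measured", "known", "first", "only" and "open" are said of these compounds alone.

The measured compounds:
Compound 1 `C=CCOc1ccc(C(=O)Nc2cccc(Br)n2)cc1`, which in an in vitro assay on HEK-tsA201 cells for antagonist activity at Neuronal acetylcholine receptor; alpha4/beta2 (Homo sapiens), read by fluorescence and calcium flux (on this read-out lower numbers stand for stronger inhibition and higher numbers for weaker inhibition), gives 70100 nM.
Compound 2 `C=CCOc1ccc(C(=O)Nc2cccc(CC)n2)cc1`, which in this assay gives 20500 nM.
Compound 3 `CCCOc1ccc(C(=O)Nc2cccc(Br)n2)cc1`, which in this assay gives 80700 nM.

Compound 3 carries the highest number of the three. Compound 1 stands within the scatter of it, the step being a 1.2-fold higher number from compound 1 to compound 3 (0.06 log units; within the scatter), while compound 2 sits clearly lower, beyond the scatter. Compound 4 `CCCOc1ccc(C(=O)Nc2cccc(CC)n2)cc1` arises from compound 3 through (ethyl in place of bromo on an aromatic carbon). For the measured compounds named here, one measured step bears directly on this change: a 3.4-fold lower number from compound 1 to compound 2 (0.53 log units; beyond the scatter), the same exchange on the same ring carbon, with the vinyl chain present instead of the propyl chain. Since the chain exchange itself, a 1.2-fold higher number from compound 1 to compound 3 (0.06 log units; within the scatter), stayed within the scatter, the bromo-to-ethyl step is expected to carry over to the propyl series. Compound 4 is therefore estimated at 24000 nM, with a range from 12000 nM to 50000 nM. That estimate amounts to an expected 3.4-fold lower number from compound 3 to compound 4 (0.53 log units; beyond the scatter), a modest lowering anticipated because a 3.4-fold lower number from compound 1 to compound 2 (0.53 log units; beyond the scatter) showed a step of that size.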

Compound 4, half-maximal inhibitory concentration: 37600 nM
Estimate against measurement, compound 4: 1.6-fold (0.19 log units) below; the measured number falls inside the stated range.
By their numbers in this assay, from the lowest: compounds 2, 4, 1 and 3 (each within the scatter of the next, the first and the last beyond it).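

For the compounds shown here, the exchange of ethyl for bromo on this aromatic carbon, next to the ring nitrogen, now also lowers the number with the propyl chain in place, a 2.1-fold lower number from compound 3 to compound 4 (0.33 log units; beyond the scatter), so the lowering is not confined to the vinyl series, and its size agrees across the two cores: the same change on two cores in this assay, a 3.4-fold lower number (0.53 log units; beyond the scatter) from compound 1 to compound 2 and a 2.1-fold lower number (0.33 log units; beyond the scatter) from compound 3 to compound 4, 1.6-fold (0.20 log units) apart, within the scatter of two such steps The chain exchange, read for the first time with ethyl on the ring, gives a 1.8-fold higher number from compound 2 to compound 4 (0.26 log units; within the scatter), which stays within the scatter as it did with bromo: the same change on two cores in this assay, a 1.2-fold higher number (0.06 log units; within the scatter) from compound 1 to compound 3 and a 1.8-fold higher number (0.26 log units; within the scatter) from compound 2 to compound 4, 1.6-fold (0.20 log units) apart, within the scatter of two such steps Across these four compounds, each change therefore reads much the same whichever group stands at the other place.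

As far as these compounds go, only bromo and ethyl appear at this ring carbon, so it remains open whether an amine or a longer chain there would lower the number further. From the compounds shown here alone, it also remains open whether the two changes would stay this independent with a longer chain on the oxygen.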